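A few compounds are considered here, and "the series" means these few. Any claim that something is new, unique, unknown or untested is made for them only; others in the source may bear on it.

Measured so far in a functional assay on RAW264.7 cells (Mus musculus) for inhibition (a lower number here means a stronger inhibitor, a higher number a weaker inhibitor), for this series:
- compound 1 `O=C1/C(=C/c2ccccc2)CCc2ccc(O)cc21` gives 710 nM
- compound 2 `O=C1/C(=C/c2cccc(F)c2)CCc2ccc(O)cc21` gives 830 nM

Among the compounds with values here, compound 1 stands level with compound 2, the only other measured compound. Compound 3 `O=C1/C(=C/c2ccccc2C(F)(F)F)CCc2ccc(O)cc21` differs from compound 1 by trifluoromethyl in place of hydrogen on an aromatic carbon and carries trifluoromethyl in place of hydrogen on an aromatic carbon, ortho to a large group. Within the data shown here, the only measured step bearing on this is a 1.2-fold higher number from compound 1 to compound 2 (0.07 log units; within the scatter) with fluoro rather than trifluoromethyl entering, so it is a weak guide. In this assay no step beyond the scatter is expected, with a slight lean towards a higher number. The estimated change is a 1.3-fold higher number from compound 1 to compound 3 (0.10 log units; within the scatter) as a central guess. For compound 3 the estimated value is 900 nM with an expected range from 350 nM to 2500 nM around it.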

Compound 3, half-maximal inhibitory concentration: 1020 nM
Beside the measured number, compound 3's estimate is 1.1-fold (0.05 log units) below it; the measured number falls inside the stated range.
By their numbers in this assay, from the lowest: compounds 1, 2 and 3 (each within the scatter of the next).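

In this assay, trifluoromethyl in place of hydrogen on an aromatic carbon, ortho to a large group, gives a 1.4-fold higher number from compound 1 to compound 3 (0.16 log units; within the scatter). A group of 4 heavy atoms is therefore accommodated at this place with no step beyond the scatter, which the fluoro step alone could not show. No measurement at hand accounts for this step. From the compounds shown here alone, how an amine or a carboxylic acid at this place would read out remains open. So does whether a longer chain there would give a step beyond the scatter.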